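A few compounds are considered here, and "the series" means these few. Any claim that something is new, unique, unknown or untested is made for them only; others in the source may bear on it.

Among the compounds with values here, compound 1 `COc1cccc(CNC(=O)c2nc(Br)c3cccnc3c2N[C@H]2CC[C@H](N)CC2)c1` is the only member of this set with a number attached to it. In a functional assay on HCT-116 cells (Homo sapiens) for cytotoxicity, read by MTT assay, with a stated time of 72 h (a higher number here means a weaker inhibitor, a lower number a stronger inhibitor), compound 1 gives 6000 nM, so within what is shown it stands alone, with no second value to set it against. A second compound, compound 2 `C[C@H](CO)Nc1nc(C(=O)NCc2ccc(F)cc2)c(O)c2ncccc12`, is built on the same core but carries a different set of substituents, and for compound 2 the outcome in this assay is recorded as "not determined" (no result reported), so it offers no point of comparison.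

Compound 3 `N[C@H]1CC[C@H](Nc2c(C(=O)NC3CCCCC3)nc(Br)c3cccnc23)CC1` has not yet been measured. It differs from compound 1 in one place only: cyclohexyl in place of 3-methoxybenzyl on an amide-type nitrogen. Within the data shown here, no measured pair in this set shows what such a swap on the amide-type nitrogen does to the read-out, so the size and direction of the step are unknown. Because compound 1 gives 6000 nM, the expectation is that compound 3 lands close to it, with the step of no change at the digits printed from compound 1 to compound 3 (within the scatter) expected to be no larger than the usual scatter. Compound 3 is therefore estimated at 6000 nM, in a range from 2000 nM to 20000 nM.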

Compound 3, half-maximal inhibitory concentration: > 10000 nM
Compound 3: only a limit was reported (the forecaster's own chance of this, stated with the estimate: 15%); middle value at least 1.6-fold (0.22 log units) away from the limit.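

On the amide-type nitrogen, cyclohexyl in place of 3-methoxybenzyl gives an at least 1.6-fold higher number from compound 1 to compound 3 (0.22 log units; that floor lies within the scatter) in this assay. Within the data shown here, this is the first reading of any change at this place, and it shows that swapping the aromatic ring of 3-methoxybenzyl for the non-aromatic ring of cyclohexyl does not bring the read-out to a lower number. In this assay compound 3 reads > 10000 nM, which is a limit and not a number, so the step has a floor but no ceiling, and its true size stays unknown: the limit of > 10000 nM in this assay, at which 1 of the 3 values shown sits.

The swap replaces the ring and the methoxy group together, so the compounds shown leave open which of the two parts of 3-methoxybenzyl counts at this place. They also leave open what a plain benzyl, a phenyl, or a longer chain ending in an amine or a carboxylic acid on the same amide-type nitrogen would do to the read-out, and whether any such group would give a number clearly lower than compound 1 shows at 6000 nM.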